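Anilide variation in an aminopyrimidine carboxamide series

The compounds below may be only part of what the source reports. "The series", "measured", "known", "first", "only" and "open" are said of these compounds alone.

Two members of the series have values in an ADME assay on BaF3 cells (Mus musculus) for antiproliferative activity, read by CellTiter-Glo and CCK-8 assay, with a stated time of 72 h; a lower number here means a stronger inhibitor of growth, a higher number a weaker inhibitor of growth. Compound 1 `Cc1ccc(Oc2ncc3c(n2)N(C)C(=O)N(c2cc(NC(=O)c4cccc(C(F)(F)F)c4)ccc2C)C3)cc1N` carries a trifluoromethyl benzamide on a cyclic core. In this assay compound 1 gives > 10000 nM, which is a limit of the assay and not a number. Compound 2 `CNc1nc(Nc2ccc(C)c([N+](=O)[O-])c2)ncc1C(=O)Nc1cc(NC(=O)c2ccccc2OC)ccc1C` is the open-chain analogue with a 2-methoxyphenyl carbonyl on the amide nitrogen. In this assay compound 2 gives > 10000 nM, again a limit and not a number. All the evidence on the series amounts to the limit of > 10000 nM in this assay, at which 2 of the 2 values shown sit, so compound 2 stands at the edge of what this assay resolves, and no order between compound 1 and compound 2 can be read.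

Compound 3 `CNc1nc(Nc2ccc(C)c([N+](=O)[O-])c2)ncc1C(=O)Nc1cc(NC(=O)c2ccc(OC)c(OC)c2)ccc1C` is the next member, not yet measured. The change from compound 2 is 3,4-dimethoxyphenyl in place of 2-methoxyphenyl on a carbonyl carbon. For the measured compounds named here, no measured step between two numbered values exists, so there is nothing to calibrate this change against. Since compound 2 returns only > 10000 nM, the expectation for compound 3 is a step no larger than the scatter, a step that the limit leaves unreadable from compound 2 to compound 3, most likely ending once more at the limit. Compound 3 is estimated at 20000 nM in this assay, expected within 5000 nM to 80000 nM.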

Compound 3, concentration for 50% growth inhibition: 7300 nM
Compound 3: the middle estimate sits 2.7-fold (0.44 log units) above what was measured; measured number inside the range.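

In this assay, for the compounds shown here, compound 3 gives 7300 nM, the first reading that is a number and not a limit, so with 3,4-dimethoxyphenyl on this carbonyl carbon the series yields a value the assay can resolve. The change from 2-methoxyphenyl to 3,4-dimethoxyphenyl gives an at least 1.3-fold lower number from compound 2 to compound 3 (0.13 log units; that floor lies within the scatter); this figure is only a floor, so the true size of the step could be larger, but these data do not fix it. A single number does not yet make a trend, and most of the series remains at the edge of the assay: the limit of > 10000 nM in this assay, at which 2 of the 3 values shown sit.

Which part of the change carries the step, the methoxy group that enters or the loss of 2-methoxyphenyl as such, stays open, since no compound shown separates the two. Also open, on these data alone, is how a plain phenyl, or a phenyl bearing an amine or a carboxylic acid, would read on this carbonyl carbon in this assay.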